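Adding a second chlorine to a core that shows no growth inhibition

The compounds below may be only part of what the source reports. "The series", "measured", "known", "first", "only" and "open" are said of these compounds alone.

Compound 1 has the structure `ClCc1ccc(Cn2cnc3c(Cl)ncnc32)cc1`. In a functional assay on COLO 205 cells (Homo sapiens) for cytotoxicity, read by sulforhodamine B assay, with a stated time of 48 h (on this read-out higher numbers stand for weaker inhibition of growth and lower numbers for stronger inhibition of growth), compound 1 gives only the limit of the assay, > 100000 nM. Two further compounds stand at the same limit: compound 2, `ClCc1cccc(Cn2cnc3ncnc(Cl)c32)c1`, gives > 100000 nM, and compound 3, `ClCc1ccc(Cn2cnc3nc(Cl)nc(Cl)c32)cc1`, gives > 100000 nM, each a limit rather than a number. For the measured compounds named here, because of the limit of > 100000 nM in this assay, at which 3 of the 3 values shown sit, no step between measured compounds can be sized. Compound 4, `ClCc1ccc(Cn2cnc3c(Cl)nc(Cl)nc32)cc1`, differs from compound 1 by chloro in place of hydrogen on an aromatic carbon. Going by the values given here, with no measured step to lean on, no change beyond the scatter is expected from compound 1 to compound 4. Compound 4 is therefore expected to give about 100000 nM in this assay, within 50000 nM to 300000 nM, a step of a number no higher from compound 1 to compound 4 (the limit leaves the size open) being the expectation.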

Compound 4, concentration for total growth inhibition: > 100000 nM
Compound 4 was reported as a limit; the forecaster's own chance of this, stated with the estimate: 85%; the middle value sits exactly at the limit.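

For the compounds shown here, no step from compound 1 to compound 4 can be read, because both values are limits and not numbers: the limit of > 100000 nM in this assay, at which 4 of the 4 values shown sit. The compounds shown leave open whether chloro in place of hydrogen on an aromatic carbon changes growth inhibition at all.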